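The compounds below may be only part of what the source reports. "The series", "measured", "known", "first", "only" and "open" are said of these compounds alone.

Measured compounds in an assay on isolated protein for inhibition of protein deacetylase HDAC6 (Homo sapiens); on this read-out lower numbers stand for stronger inhibition and higher numbers for weaker inhibition:

- compound 1, `COc1cc(C(=O)c2ccc3c(ccn3S(=O)(=O)c3cccc(/C=C/C(=O)NO)c3)c2)cc(OC)c1OC`: 562 nM
- compound 2, `COc1ccc(C(=O)c2ccc3c(ccn3S(=O)(=O)c3cccc(/C=C/C(=O)NO)c3)c2)cc1`: 751 nM
- compound 3, `COc1cc(C(=O)c2ccc3c(ccn3Cc3ccc(/C=C/C(=O)NO)cc3)c2)cc(OC)c1OC`: 143 nM

Compound 1 and compound 2 share one core; compound 3 carries a different core, and the difference between the two cores is not broken down here. Within the first core, the single change from compound 1 to compound 2 is 4-methoxyphenyl in place of 3,4,5-trimethoxyphenyl on a carbonyl carbon, and the step it made is a 1.3-fold higher number from compound 1 to compound 2 (0.13 log units; within the scatter). So the two values show no separation that this assay can resolve.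

Compound 3 gives the lowest number of the three, and its steps to compound 1 and to compound 2 are both beyond the scatter, so within this small set it is the strongest inhibitor.

Compound 4, `COc1ccc(C(=O)c2ccc3c(ccn3Cc3ccc(/C=C/C(=O)NO)cc3)c2)cc1`, is not yet measured in this assay. It arises from compound 3 by 4-methoxyphenyl in place of 3,4,5-trimethoxyphenyl on a carbonyl carbon, the same change as from compound 1 to compound 2: the group that leaves, the group that enters and the place are the same. The expectation rests on that earlier pair, where compound 2 against compound 1 showed a 1.3-fold higher number from compound 1 to compound 2 (0.13 log units; within the scatter). A step of about a 1.3-fold higher number from compound 3 to compound 4 (0.12 log units; within the scatter) from compound 3 to compound 4 is therefore expected, which would keep compound 4 close to compound 3. The estimate for compound 4 in this assay is 190 nM, expected to lie between 90 nM and 400 nM.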

Compound 4, half-maximal inhibitory concentration: 108 nM
Compound 4: the middle estimate sits 1.8-fold (0.25 log units) above what was measured; the range from low to high includes it.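

In this assay, 4-methoxyphenyl in place of 3,4,5-trimethoxyphenyl on a carbonyl carbon gives a 1.3-fold lower number from compound 3 to compound 4 (0.12 log units; within the scatter), so on the core of compound 3 this read-out does not separate the two groups. Set beside the earlier step, the result on the two cores agrees: the change stays within the scatter on each, and the two steps cannot be told apart: the same change on two cores in this assay, a 1.3-fold higher number (0.13 log units; within the scatter) from compound 1 to compound 2 and a 1.3-fold lower number (0.12 log units; within the scatter) from compound 3 to compound 4, 1.8-fold (0.25 log units) apart, within the scatter of two such steps. This supports carrying the change between these two cores as one that leaves the number unresolved, but it does not show a direction for the change on either core, and two cores are a narrow basis for any wider rule in the series.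

The compounds shown leave open whether a group on the carbonyl carbon further from these two, such as an unsubstituted phenyl, or a phenyl carrying an amine or a carboxylic acid, would give a step that this assay can resolve. They also leave open which part of the difference between the two cores goes with the gap between their numbers, as no pair shown changes that difference in one place.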